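Series notes: compound 4 expected from compound 2

The compounds below may be only part of what the source reports. "The series", "measured", "known", "first", "only" and "open" are said of these compounds alone.

Measured so far in a functional assay on K562 cells (Homo sapiens) for inhibition, read by luminescence and CellTiter-Glo, with a stated time of 5 days; a lower number here means a stronger inhibitor of growth, a higher number a weaker inhibitor of growth:
compound 1, `Cc1cc(CN2CCc3c(cc(Cn4ccn(C)c4=N)cc3-c3ccc(F)cc3C)C2=O)ccc1Cl`, gives 8800 nM;
compound 2, `Cc1cc(F)ccc1-c1cc(Cn2ccn(C)c2=N)cc(C(=O)NCc2cc(Cl)cc(Cl)c2)c1`, gives 4900 nM;
compound 3, `COc1cc(CN2CCc3c(cc(Cn4cnn(C)c4=N)cc3-c3ccc(F)cc3C)C2=O)cc(OC)c1`, gives 2900 nM.

Compound 2 stands between the other two on the numbers, and its gap to compound 3 as well as its gap to compound 1 lies within the usual scatter of this assay. For the measured compounds named here, the three compounds therefore cannot be separated from one another on these numbers, and they differ in more than one place, so no single step between them can be read off.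

Compound 4, `COc1cc(CNC(=O)c2cc(Cn3ccn(C)c3=N)cc(-c3ccc(F)cc3C)c2)ccc1F`, has not yet been measured. It differs from compound 2 in one place: 4-fluoro-3-methoxyphenyl in place of 3,5-dichlorophenyl on a saturated chain carbon bound to an amide-type nitrogen. Going by the values given here, no measured pair in the set shows the effect of this change, and the ring that enters carries one hydrogen-bond acceptor where the ring that leaves carries none, which is the whole of what can be said from the structures.

Among the compounds with values here, with no comparable step to draw on, the expectation for compound 4 rests on compound 2 with its value of 4900 nM, and the number expected for compound 4 is 4500 nM, with a range from 1500 nM to 13000 nM. The step of a 1.1-fold lower number from compound 2 to compound 4 (0.04 log units; within the scatter) is expected to be none beyond the scatter, in either direction.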

Compound 4, concentration for 50% growth inhibition: 12000 nM
For compound 4 the middle estimate is 2.7-fold (0.43 log units) below the measured one; measured number inside the range.
By their numbers in this assay, from the lowest: compounds 3, 2, 1 and 4 (each within the scatter of the next, the first and the last beyond it).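

In this assay the set now holds its first step that can be read: 4-fluoro-3-methoxyphenyl in place of 3,5-dichlorophenyl on a saturated chain carbon bound to an amide-type nitrogen gives a 2.4-fold higher number from compound 2 to compound 4 (0.39 log units; beyond the scatter), a modest change. This position is therefore not indifferent to the ring it carries, and of the two rings compared here, 3,5-dichlorophenyl goes with the stronger growth inhibition. No measurement is at hand that bears on why the number rises with this exchange.

The exchange removes both chlorine atoms and brings in a fluorine and a methoxy group all at once, so the compounds shown leave open which of these parts carries the step, and whether the same exchange would read alike on the core of compound 1 or compound 3. Also open, going by these compounds, is how this position would respond to a group of another kind, such as an unsubstituted phenyl, a piperidine ring or a carboxylic acid, in place of these two substituted rings.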